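Amino in Place of Hydroxy: Expecting Compound 4

The source may hold more compounds than are shown below. What is called first, only, known or untested is meant among the compounds shown, and "the series" means these compounds.

Compound 1 `CCCN(C)c1ncnc2[nH]cc(-c3cccc(Cl)c3)c12` gives 208 nM in an assay for inhibition of serine/threonine-protein kinase 4 (Homo sapiens), read by luminescence and ADP-Glo, in the presence of a further agent that is not named here; a lower number here means a stronger inhibitor, a higher number a weaker inhibitor.
Compound 2 `OC1CCN(c2ncnc3[nH]cc(-c4cccc(Cl)c4)c23)CC1` gives 80 nM in this assay.
Compound 3 `CC1(O)CCN(c2ncnc3[nH]cc(-c4cccc(Cl)c4)c23)CC1` gives 145 nM in this assay.

Going by the values given here, compound 3 sits between the other two numbers: a 1.8-fold higher number from compound 2 to compound 3 (0.26 log units; within the scatter) and a 1.4-fold lower number from compound 1 to compound 3 (0.16 log units; within the scatter) are both within the scatter, so the three are hardly set apart, while a 2.6-fold lower number from compound 1 to compound 2 (0.41 log units; beyond the scatter) is the only step beyond it. Compound 4 `CC1(N)CCN(c2ncnc3[nH]cc(-c4cccc(Cl)c4)c23)CC1` differs from compound 3 by amino in place of hydroxy on a saturated ring carbon. Among the compounds with values here, no measured step swaps hydroxy for amino; the one change at this same ring carbon, a 1.8-fold higher number from compound 2 to compound 3 (0.26 log units; within the scatter), stayed within the scatter. For compound 4 the expected step is therefore a 1.0-fold higher number from compound 3 to compound 4 (0.01 log units; within the scatter), none beyond the scatter in this assay. Compound 4 is estimated at 150 nM, with a range from 60 nM to 400 nM.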

Compound 4, half-maximal inhibitory concentration: 163 nM
The estimate for compound 4 lay 1.1-fold (0.04 log units) below the measured number, within the range that was stated.
By their numbers in this assay, from the lowest: compounds 2, 3, 4 and 1 (each within the scatter of the next, the first and the last beyond it).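

In this assay, amino and hydroxy on this saturated ring carbon cannot be told apart, as a 1.1-fold higher number from compound 3 to compound 4 (0.05 log units; within the scatter) stays within the scatter, and this is the first swap of these two groups shown. The amino compound is set apart only modestly from the unmethylated hydroxy compound, by a 2.0-fold higher number from compound 2 to compound 4 (0.31 log units; beyond the scatter), while a 1.3-fold lower number from compound 1 to compound 4 (0.11 log units; within the scatter) stays within the scatter. Nothing measured here explains these results.

The compounds shown leave open what 4-aminopiperidin-1-yl, the amino group without the methyl, would give. From the compounds shown here alone, a carboxylic acid or an aminomethyl chain on this ring carbon also remains open.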